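1-Methylpiperidin-4-yl to 1-methylpyrrolidin-3-yl: working notes on the series

The source may report more compounds than this note shows. Statements on the series, on what has been measured and on what is new or still open speak of the compounds shown alone.

Compound 1 `Cc1cc2nnccc2cc1Nc1ncc2c(n1)n(C1CCOCC1)c(=O)n2C` (2.2)
Compound 2 `Cc1cc2ncccc2cc1Nc1ncc2c(n1)n(C1CCN(C)CC1)c(=O)n2C` (1.8)

In a physicochemical assay for lipophilicity, read by HPLC, using the shake flask method, measured as octanol-water partition, at pH 7.4 (on this read-out higher numbers stand for higher lipophilicity and lower numbers for lower lipophilicity), compound 2 stands lowest of the two measured compounds at 1.8, and the gap to compound 1, which gives 2.2, lies beyond the scatter. Among the compounds with values here, these two compounds differ in more than one place, so the series offers no measured single-change step as a guide.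

Compound 3 `Cc1cc2ncccc2cc1Nc1ncc2c(n1)n([C@H]1CCN(C)C1)c(=O)n2C` has 1-methylpyrrolidin-3-yl in place of 1-methylpiperidin-4-yl on an aromatic nitrogen and remains unmeasured. Within the data shown here, with no measured precedent for this change, only a small fall in this assay is expected, one that stays within the scatter. The expected shift is a number 0.20 log units lower from compound 2 to compound 3 (within the scatter) and this is an estimate with wide uncertainty. For compound 3 the expected value is 1.6 (estimated range 1.2 to 2).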

Compound 3, distribution coefficient: 1.1
For compound 3 the middle estimate is 0.50 log units above the measured one; the measured number lies below the stated range.
By their numbers in this assay, from the lowest: compound 3; then compound 2; then compound 1.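

Within the data shown here, putting 1-methylpyrrolidin-3-yl in place of 1-methylpiperidin-4-yl on an aromatic nitrogen gives the first single-change step, and in this assay it reads a number 0.70 log units lower from compound 2 to compound 3 (beyond the scatter). The read-out at this position therefore responds to swapping a six-membered non-aromatic ring for a five-membered one that carries a defined stereocentre, with the ring nitrogen methylated in both. Nothing at hand accounts for the size of this step, which stands as an observation on this one pair.

Open, going by these compounds, is whether the opposite configuration at the stereocentre of 1-methylpyrrolidin-3-yl gives the same reading. Also open, on these data alone, is whether a smaller ring such as 1-methylazetidin-3-yl, or an open-chain 2-(dimethylamino)ethyl group, on the same nitrogen would continue the step in the same direction.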